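Swapping chloro for methyl on the sulfamoyl-bearing ring

The source may hold more compounds than are shown below. What is called first, only, known or untested is meant among the compounds shown, and "the series" means these compounds.

Three cyanoguanidines built on one shared core have been measured in an assay on CHO cells for displacement of a labelled ligand from C-X-C chemokine receptor type 1 (Homo sapiens); on this read-out lower numbers stand for stronger inhibition and higher numbers for weaker inhibition. Compound 1 `CN(C)S(=O)(=O)c1c(Cl)ccc(N/C(=N/C#N)Nc2ccccc2Br)c1O` gives 55 nM, the lowest number of the three. Compound 2 `CCc1ccccc1N/C(=N\C#N)Nc1ccc(Cl)c(S(=O)(=O)N(C)C)c1O` gives 512 nM, and compound 3 `CN(C)S(=O)(=O)c1c(Cl)ccc(N/C(=N/C#N)Nc2cccc(Cl)c2F)c1O` gives 6200 nM. Among the compounds with values here, all of the measured steps concern the second aromatic ring, the one that carries bromo, ethyl, or chloro and fluoro: a 9.3-fold higher number from compound 1 to compound 2 (0.97 log units; beyond the scatter), a 110-fold higher number from compound 1 to compound 3 (2.05 log units; beyond the scatter), and a 12-fold higher number from compound 2 to compound 3 (1.08 log units; beyond the scatter).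

Compound 4 `Cc1ccc(N/C(=N/C#N)Nc2ccccc2Br)c(O)c1S(=O)(=O)N(C)C` has not yet been measured. It differs from compound 1 in a single place: methyl in place of chloro on an aromatic carbon. Within the data shown here, this position is untouched among the measured compounds, so none of the measured steps bears directly on it; they show only that changes elsewhere on this core can move this assay by modest to large amounts. Without direct evidence, the change from compound 1 to compound 4 is expected to be small, with its direction uncertain, and the estimate leans slightly toward a higher number: a 1.8-fold higher number from compound 1 to compound 4 (0.26 log units; within the scatter). Compound 4 is therefore expected to give about 100 nM, with a range from 25 nM to 400 nM that allows for either direction.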

Compound 4, half-maximal inhibitory concentration: 187 nM
For compound 4 the middle estimate is 1.9-fold (0.27 log units) below the measured one; measured number inside the range.
By their numbers in this assay, from the lowest: compound 1; then compound 4; then compound 2; then compound 3.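

In this assay, methyl in place of chloro on this aromatic carbon gives a 3.4-fold higher number from compound 1 to compound 4 (0.53 log units; beyond the scatter) and so shows that this position, ortho to a dimethylsulfamoyl group and meta to a hydroxy group, is not indifferent to a change of a single atom. The earlier compounds shown here could not show this, since all their steps lay on the second aromatic ring, whereas this step shows that the ring carrying the sulfamoyl group can also move the read-out. Chloro and methyl have the same counts of heavy atoms, hydrogen-bond donors and acceptors, and neither carries a net charge, so those counts do not separate the two groups, and nothing shown here explains the difference between them.

With only chloro and methyl shown at this position, it remains open how a larger or differently built group, such as methoxy, an amine, or a longer chain like ethyl, would behave there. From the compounds shown here alone, it is also open whether the same swap would give a step of similar size on a core carrying the 2-ethylphenyl or 3-chloro-2-fluorophenyl group instead of 2-bromophenyl.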